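The compounds below may be only part of what the source reports. "The series", "measured", "known", "first", "only" and "open" are said of these compounds alone.

Measured so far:
- compound 1 `COc1cc(-c2cc(/C=C/C(=O)c3ccc(N)cc3)[nH]n2)cc(OC)c1OC`: -64%
- compound 2 `COc1cc(-c2cc(/C=C/C(=O)c3ccc(Cl)c(Cl)c3)[nH]n2)cc(OC)c1OC`: 9%

In a functional assay on RXF 393 cells (Homo sapiens) for cytotoxicity, read by sulforhodamine B assay, with a stated time of 48 h, tested at 10 uM (on this read-out lower numbers stand for a stronger effect and higher numbers for a weaker effect at the one concentration tested), compound 2 gives the highest of the two numbers; its nearest neighbour is compound 1, and the step of a number 73 percentage points higher from compound 1 to compound 2 (beyond the scatter) is the only one available, a large rise in the read-out on moving from 4-aminophenyl to 3,4-dichlorophenyl on the carbonyl carbon. The next compound, compound 3 `COc1ccc(C(=O)/C=C/c2cc(-c3cc(OC)c(OC)c(OC)c3)n[nH]2)cc1OC`, is not yet measured. Relative to compound 2 the change is 3,4-dimethoxyphenyl in place of 3,4-dichlorophenyl on a carbonyl carbon: 3,4-dimethoxyphenyl in place of 3,4-dichlorophenyl on the carbonyl carbon, the shared core otherwise unchanged.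

The step from compound 1 to compound 2 shows this position can move the read-out a long way, but neither measured compound carries the entering group, so the direction is not fixed by the data. Compound 3 keeps two acceptors where compound 2 had none and falls between the two measured cases in that respect, so a downward step a number 24 percentage points lower from compound 2 to compound 3 (beyond the scatter) of moderate size is expected, with wide uncertainty. For compound 3 the estimate in this assay is -15%, expected to lie between -55% and 20%.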

Compound 3, a percentage reported as activity, at one concentration (the size of the read-out at that concentration, not a potency): -98%
Compound 3: the middle estimate sits 83 percentage points above what was measured, outside the stated range (below it).
By their numbers in this assay, from the lowest: compound 3; then compound 1; then compound 2.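

In this assay, 3,4-dimethoxyphenyl in place of 3,4-dichlorophenyl on the carbonyl carbon gives a number 107 percentage points lower from compound 2 to compound 3 (beyond the scatter) and this shows that a substituted phenyl at this place can push the read-out well past the level reached with 4-aminophenyl. Against that group the same entering group gives a number 34 percentage points lower from compound 1 to compound 3 (beyond the scatter) so compound 3 has the strongest effect of the three, followed by compound 1 and then compound 2, with the shared core otherwise unchanged. No measured evidence accounts for this order, and the counts alone cannot settle it, as the entering group differs from 3,4-dichlorophenyl both in its hydrogen-bond acceptors and in its heavy atoms.

The compounds shown leave open whether both methoxy groups are needed, which a phenyl carrying a single methoxy group or an unsubstituted phenyl would address. They also leave open whether the oxygen must be present as an ether, which a phenyl carrying hydroxyl groups in place of the methoxy groups would test on the same core.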